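The source may hold more compounds than are shown below. What is called first, only, known or untested is meant among the compounds shown, and "the series" means these compounds.

Compound 1 `CCCCCCCCCCCCCCCCCCNC(=O)[C@H]1CSC(c2cccc(O)c2)N1` opens the set; in a functional assay on PC-3 cells (Homo sapiens) for antiproliferative activity, read by sulforhodamine B assay (a lower number here means a stronger inhibitor, a higher number a weaker inhibitor), compound 1 gives 6700 nM. Compound 2 `CCCCCCCCCCCCCCCCCCNC(=O)[C@H]1CSC(c2ccc([N+](=O)[O-])cc2)N1`, carrying a 4-nitrophenyl on the saturated ring carbon, gives about 20000 nM in this assay. Compound 3 `CCCCCCCCCCCCCCCCCCNC(=O)[C@H]1CSC(c2cc(F)cc(F)c2)N1` bears a 3,5-difluorophenyl at that carbon. In this assay compound 3 reaches only a limit of the assay, > 20000 nM. Compound 3 thus stands at the limit and no lower than compound 2; an at least 2.9-fold higher number from compound 1 to compound 3 (0.47 log units; beyond the scatter) is at least modest, as is a 3.0-fold higher number from compound 1 to compound 2 (0.47 log units; beyond the scatter), while a number no lower from compound 2 to compound 3 (the limit leaves the size open) cannot be sized. Compound 4 `CCCCCCCCCCCCCCCCCCNC(=O)[C@H]1CSC(c2ccc(F)c(Br)c2)N1` differs from compound 3 in one place: 3-bromo-4-fluorophenyl in place of 3,5-difluorophenyl on a saturated ring carbon. Both replacements of the 3-hydroxyphenyl raised the number, and the 3,5-difluorophenyl of compound 3 already sits at the limit, so in this assay the expected step is a number no higher from compound 3 to compound 4 (the limit leaves the size open), none beyond the scatter. Compound 4 is estimated at 20000 nM, within 8000 nM to 50000 nM, and may again reach only a limit.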

Compound 4, half-maximal inhibitory concentration: 13500 nM
Compound 4: the middle estimate sits 1.5-fold (0.17 log units) above what was measured; measured number inside the range.
By their numbers in this assay, from the lowest: compounds 1, 4 and 2 (each within the scatter of the next, the first and the last beyond it).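

In this assay the 3-bromo-4-fluorophenyl gives this carbon a measured number, whereas compound 3 gives only a limit: the limit of > 20000 nM in this assay, at which 1 of the 4 values shown sits. Against that limit the change reads as an at least 1.4-fold lower number from compound 3 to compound 4 (0.17 log units; that floor lies within the scatter), so it shows no gain beyond the scatter. Both a 1.5-fold lower number from compound 2 to compound 4 (0.17 log units; within the scatter) and a 2.0-fold higher number from compound 1 to compound 4 (0.30 log units; within the scatter) leave the new group indistinguishable from the 4-nitrophenyl or the 3-hydroxyphenyl, though those two differ beyond the scatter. On these data alone, what an aminophenyl or a carboxyphenyl would give at this carbon stays open, as does the effect of a shorter chain on the amide.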